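A few compounds are considered here, and "the series" means these few. Any claim that something is new, unique, unknown or untested is made for them only; others in the source may bear on it.

Values in a functional assay on T47D cells (Homo sapiens) for cytotoxicity, read by sulforhodamine B assay, with a stated time of 48 h, tested at 1 uM (on this read-out higher numbers stand for a weaker effect at the one concentration tested and lower numbers for a stronger effect), for the measured members of the series:
compound 1 `COc1cc(-c2cc(/C=C/C(=O)c3ccc(N)cc3)[nH]n2)cc(OC)c1OC` gives 66%
compound 2 `COc1ccc(-c2cc(/C=C/C(=O)c3ccc(N)cc3)[nH]n2)cc1OC` gives 87%
compound 3 `COc1ccc(-c2cc(/C=C/C(=O)c3ccc(N)cc3)[nH]n2)cc1` gives 60%

Compound 1 stands second highest of the three; its value and that of compound 3 lie within the scatter of each other, while compound 2 sits higher by a number 21 percentage points higher from compound 1 to compound 2 (beyond the scatter), beyond the scatter. The two recorded steps, a number 21 percentage points higher from compound 1 to compound 2 (beyond the scatter) and a number 27 percentage points lower from compound 2 to compound 3 (beyond the scatter), both concern a methoxy on the aryl ring attached to the shared core, not the aryl ring on the carbonyl carbon.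

Compound 4 `COc1cc(-c2cc(/C=C/C(=O)c3ccc(F)c(F)c3)[nH]n2)cc(OC)c1OC` differs from compound 1 by 3,4-difluorophenyl in place of 4-aminophenyl on a carbonyl carbon. Among the compounds with values here, no measured step touches this position, so the recorded steps bear on it only as a measure of how far the series moves at all. The expected change is a number 2 percentage points higher from compound 1 to compound 4 (within the scatter), not clearly beyond the scatter. Compound 4 is estimated at 68%, within 45% to 92%.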

Compound 4, a percentage reported as activity, at one concentration (the size of the read-out at that concentration, not a potency): 76%
Compound 4: middle estimate off by 8 percentage points, on the low side; the measured number falls inside the stated range.
By their numbers in this assay, from the lowest: compounds 3, 1 and 4 (each within the scatter of the next, the first and the last beyond it); then compound 2.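

In this assay, the first step read on a carbonyl carbon's aryl group is a number 10 percentage points higher from compound 1 to compound 4 (within the scatter). On the core of compound 1, the two numbers therefore stay within the scatter of each other, even though 4-aminophenyl carries 1 hydrogen-bond donor and 1 hydrogen-bond acceptor and 3,4-difluorophenyl carries neither. Nothing available accounts for this result.

Still open, going by these compounds, is whether a carboxylic acid or a dimethylamino group on this aryl ring would give a similar number. Also open, on these data alone, is whether the same exchange reads alike on the cores of compound 2 and compound 3.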